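The compounds below may be only part of what the source reports. "The series", "measured", "known", "first", "only" and "open" are said of these compounds alone.

Working notes on the series. Within the data shown here, in a functional assay on Jurkat cells (Homo sapiens) for antiproliferative activity, read by MTT assay, with a stated time of 48 h (on this read-out lower numbers stand for stronger inhibition and higher numbers for weaker inhibition), compound 1 (`COc1ccc(Nc2nc(Nc3cnn(CCCCCCC(=O)NO)c3)ncc2Cl)cc1`) gives 130 nM and compound 2 (`O=C(CCCCCCn1cc(Nc2ncc(Cl)c(Nc3ccc(F)cc3)n2)cn1)NO`) gives 120 nM, so compound 2 stands level with the only other measured compound, within the scatter. Compound 3 (`O=C(CCCCCCn1cc(Nc2ncc(Cl)c(Nc3ccccc3)n2)cn1)NO`) departs from compound 2 by one change: hydrogen in place of fluoro on an aromatic carbon. Among the measured compounds shown here, one measured step bears on this, fluoro in place of methoxy on an aromatic carbon: a 1.1-fold lower number from compound 1 to compound 2 (0.03 log units; within the scatter), within the scatter. On that single step, no change beyond the scatter is expected in this assay, and no direction is favoured, although removal of the fluoro itself remains unmeasured. The expected step is a 1.0-fold higher number from compound 2 to compound 3 (0.02 log units; within the scatter). Compound 3 is estimated at 125 nM, with an expected range of 65 nM to 240 nM.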

Compound 3, half-maximal inhibitory concentration: 90 nM
Estimate against measurement, compound 3: 1.4-fold (0.14 log units) above; low and high end bracket the measured number.
By their numbers in this assay, from the lowest: compounds 3, 2 and 1 (each within the scatter of the next).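

In this assay the step from fluoro to hydrogen gives a 1.3-fold lower number from compound 2 to compound 3 (0.12 log units; within the scatter) and the step from methoxy to hydrogen gives a 1.4-fold lower number from compound 1 to compound 3 (0.16 log units; within the scatter) so neither group can be told apart from plain hydrogen at this place, para to a large group. The earlier pair compared only one substituent with another, whereas the plain phenyl now shows that the number holds with no substituent here at all, across the three compounds shown. No measurement at hand accounts for this flat reading.

On these data alone, whether an amine or a carboxylic acid at this place would move the number beyond the scatter remains open. Among these compounds, also open is whether a longer chain in place of the one shared by these compounds would change the number.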